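The source may report more compounds than this note shows. Statements on the series, on what has been measured and on what is new or still open speak of the compounds shown alone.

Three compounds share one core and differ only in the group carried on the amide nitrogen. Compound 1 `COc1ccc(NC(=O)COc2cc(C)nc3ccc(OC)cc23)cc1` carries a 4-methoxyphenyl group there. In an ADME assay on HepG2 cells (Homo sapiens) for cytotoxicity, read by trypan blue exclusion, with a stated time of 48 h, in the presence of a further agent that is not named here (on this read-out lower numbers stand for higher toxicity in this test and higher numbers for lower toxicity in this test), compound 1 gives only a limit, > 142000 nM. Compound 2 `COc1ccc2nc(C)cc(OCC(=O)Nc3ccc(Br)cc3)c2c1` gives in this assay only a limit, > 125000 nM. Compound 3 `COc1ccc2nc(C)cc(OCC(=O)Nc3ccc(-c4ccccc4)cc3)c2c1` gives in this assay only a limit, > 126000 nM. Compound 2 therefore stands among values that are all limits, none a true number. The steps a step that the two limits leave unreadable from compound 1 to compound 2, a step that the two limits leave unreadable from compound 1 to compound 3 and a step that the two limits leave unreadable from compound 2 to compound 3 bear on the change studied here, yet their sizes cannot be read. Compound 4 `COc1ccc2nc(C)cc(OCC(=O)NCCCc3ccccc3)c2c1` arises from compound 2 by the change (3-phenylpropyl in place of 4-bromophenyl on an amide-type nitrogen). With every measured value sitting at a limit, the step from compound 2 to compound 4 is expected to be a number no higher from compound 2 to compound 4 (the limit leaves the size open), nothing beyond the scatter. Compound 4 is expected at 125000 nM, within 60000 nM to 300000 nM, most likely reported again as a limit.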

Compound 4, half-maximal cytotoxic concentration: > 137000 nM
Compound 4: a limit, no number (the forecaster's own chance of this, stated with the estimate: 85%); at least 1.0-fold (0.03 log units) between middle value and limit.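

Compound 4, like compound 1 and compound 2, gives only a limit in this assay, and the steps to compound 4 from compound 1 and compound 2 cannot be read. The compounds shown leave open at what concentration any of them becomes toxic, and whether the group on the amide nitrogen matters.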